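Swapping a fluorophenyl for a pyridine ring in an oxindole series

The source may hold more compounds than are shown below. What is called first, only, known or untested is meant among the compounds shown, and "the series" means these compounds.

Measured so far:
- Compound 1, `O=C1Nc2c(ccc(F)c2F)C1(c1ccc(O)cc1)c1ccc(F)cc1`: 8.6 nM
- Compound 2, `CCOc1ccc(C2(c3ccc(O)cc3)C(=O)Nc3c2ccc(F)c3F)cc1`: 24 nM
- Compound 3, `COc1ccc(C2(c3cccc(O)c3)C(=O)Nc3c2ccc(F)c3F)cc1`: 145 nM

These three compounds share a core and were tested in a functional assay on PC-3 cells (Homo sapiens) for cytotoxicity, read by WST assay, with a stated time of 72 h; on this read-out lower numbers stand for stronger inhibition and higher numbers for weaker inhibition. Compound 1 gives the lowest number of the three in this assay, 8.6 nM; compound 2 is the nearest neighbour and compound 3 the furthest. Among the compounds with values here, the one single-point change among them is a 2.8-fold higher number from compound 1 to compound 2 (0.45 log units; beyond the scatter).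

The untested compound 4, `O=C1Nc2c(ccc(F)c2F)C1(c1ccc(O)cc1)c1cccnc1`, differs from compound 1 in a single place: pyridin-3-yl in place of 4-fluorophenyl on a saturated ring carbon. Within the data shown here, no measured step swaps one aromatic ring for another, so the only guide to the size of such a change is the single-point step from compound 1 to compound 2, which was modest and beyond the scatter. Compound 3 carries two changes at once and cannot be tied to this step alone. A change at the same ring position in compound 1 therefore seems likely to move the number modestly upward rather than leave it untouched, though a result within the scatter cannot be ruled out.

For compound 4 the expected step is a 2.9-fold higher number from compound 1 to compound 4 (0.46 log units; beyond the scatter). Compound 4 is therefore estimated at 25 nM, with a range from 8 nM to 80 nM.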

Compound 4, half-maximal inhibitory concentration: > 1000 nM
Compound 4: only a limit was reported; the forecaster's own chance of this, stated with the estimate: 2%; at least 40-fold (1.60 log units) between middle value and limit.
By their numbers in this assay, from the lowest: compound 1; then compound 2; then compound 3. At a limit, above all of these: compound 4.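

In this assay the reading for compound 4 is a limit of the assay and not a number: the limit of > 1000 nM in this assay, at which 1 of the 4 values shown sits. Even so, it shows that this position on the saturated ring carbon is far more sensitive than the earlier compounds suggested, with pyridin-3-yl in place of 4-fluorophenyl giving an at least 110-fold higher number from compound 1 to compound 4 (2.06 log units; beyond the scatter), while ethoxy in place of fluoro on the phenyl ring gave only a 2.8-fold higher number from compound 1 to compound 2 (0.45 log units; beyond the scatter). The comparison with the 4-ethoxyphenyl ring points the same way, with pyridin-3-yl giving an at least 41-fold higher number from compound 2 to compound 4 (1.61 log units; beyond the scatter), so among these compounds, changing the group on the phenyl ring costs much less than exchanging that ring for one with a ring nitrogen.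

As far as these compounds go, how far past its limit compound 4 lies stays open, and with it the full size of both new steps. From the compounds shown here alone, it is also open whether the ring nitrogen or the loss of the fluorine matters more, a question that a plain phenyl or a pyridin-4-yl ring at this place could help to separate.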